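A few compounds are considered here, and "the series" means these few. Any claim that something is new, unique, unknown or untested is made for them only; others in the source may bear on it.

Among the measured compounds shown here, compound 2 `Fc1ccccc1/C=N/c1sc2c(c1-c1nc3ccccc3s1)CCC2` gives 355 ug/mL in an ADME assay on HeLa cells (Homo sapiens) for cytotoxicity, read by MTT assay, with a stated time of 72 h (a lower number here means that less compound is tolerated, a higher number that more compound is tolerated), the higher of the two numbers measured so far. Its nearest neighbour, compound 1 `Nc1sc2c(c1-c1nc3cc(Cl)ccc3s1)CCCC2`, gives 107 ug/mL in this assay, a gap beyond the scatter. Compound 3 `Oc1ccccc1/C=N/c1sc2c(c1-c1nc3ccccc3s1)CCC2` differs from compound 2 by a single change: hydroxy in place of fluoro on an aromatic carbon. For the measured compounds named here, no pair of measured compounds carries this change, so there is nothing in the data to set its size or direction. The expectation is therefore for a step from compound 2 to compound 3 of a 1.1-fold lower number from compound 2 to compound 3 (0.05 log units; within the scatter), which is no move beyond the scatter, with either direction left open. For compound 3 the estimated value in this assay is 320 ug/mL, and the expected range runs from 150 ug/mL to 700 ug/mL.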

Compound 3, half-maximal cytotoxic concentration: 168 ug/mL
Compound 3: the middle estimate sits 1.9-fold (0.28 log units) above what was measured; the measured number falls inside the stated range.
By their numbers in this assay, from the lowest: compounds 1 and 3 (each within the scatter of the next); then compound 2.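

In this assay, among the compounds shown here, the change from 2-fluorophenyl to 2-hydroxyphenyl gives a 2.1-fold lower number from compound 2 to compound 3 (0.32 log units; beyond the scatter) and is the first measured evidence on this place, on an aromatic carbon ortho to a large group. The substituent here is therefore not indifferent: the swap moves the number beyond the scatter, towards less compound tolerated, although the step is modest and rests on this single pair. The entering hydroxy brings a hydrogen-bond donor and a hydrogen-bond acceptor that fluoro lacks, but nothing measured connects these counts to the step.

As far as these compounds go, whether an amine or a methoxy group at this place would sit with the hydroxy or with the fluoro remains open. Also open, from the compounds shown here alone, is whether the same change gives a step of similar size and direction on another core.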